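Ester variation on a bicyclic enone: cytotoxicity notes

The source may report more compounds than this note shows. Statements on the series, on what has been measured and on what is new or still open speak of the compounds shown alone.

Measured so far:
- compound 1, `CC(=O)O[C@]12C=CC(=O)C[C@H]1OCC2`: 4.1 ug/mL
- compound 2, `CCCC(=O)O[C@]12C=CC(=O)C[C@H]1OCC2`: 2.7 ug/mL
- compound 3, `CCCCCCCC(=O)O[C@]12C=CC(=O)C[C@H]1OCC2`: 0.8 ug/mL

In a functional assay on HeLa S3 cells (Homo sapiens) for cytotoxicity (on this read-out higher numbers stand for weaker inhibition and lower numbers for stronger inhibition), compound 2 sits second highest of the three numbers; its nearest neighbour is compound 1, with a 1.5-fold lower number from compound 1 to compound 2 (0.18 log units; within the scatter) lying within the scatter, and its furthest is compound 3, reached by a 3.4-fold lower number from compound 2 to compound 3 (0.53 log units; beyond the scatter). Compound 4, `O=C1C=C[C@]2(OC(=O)c3ccccc3)CCO[C@@H]2C1`, is not yet measured. It differs from compound 2 by phenyl in place of propyl on a carbonyl carbon.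

Within the data shown here, the steps that bear on this change all concern the acyl group: a 1.5-fold lower number from compound 1 to compound 2 (0.18 log units; within the scatter), a 5.1-fold lower number from compound 1 to compound 3 (0.71 log units; beyond the scatter) and a 3.4-fold lower number from compound 2 to compound 3 (0.53 log units; beyond the scatter). Each addition of carbons to the chain lowered the number, and the two larger additions did so beyond the scatter. Phenyl brings six carbons, as counted, but in an aromatic ring rather than a chain, so no measured step matches it exactly. A modest lowering, between the two larger steps seen, is expected.

For compound 4 the estimate is 1.4 ug/mL (range 0.5 ug/mL to 4 ug/mL), which is expected to correspond to a 1.9-fold lower number from compound 2 to compound 4 (0.29 log units; within the scatter).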

Compound 4, half-maximal inhibitory concentration: 1.6 ug/mL
The estimate for compound 4 lay 1.1-fold (0.06 log units) below the measured number; measured number inside the range.
By their numbers in this assay, from the lowest: compounds 3, 4, 2 and 1 (each within the scatter of the next, the first and the last beyond it).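

Notes on the acyl position: in this assay, phenyl in place of propyl on the carbonyl carbon gives a 1.7-fold lower number from compound 2 to compound 4 (0.23 log units; within the scatter) and so leaves the two groups unseparated. Phenyl in place of methyl gives a 2.6-fold lower number from compound 1 to compound 4 (0.41 log units; beyond the scatter) and, unlike that first step, lies beyond the scatter, so at this position a lower number than that of compound 1 is reached with an aromatic ring as well as with a saturated chain. Compound 3 at 0.8 ug/mL and compound 4 at 1.6 ug/mL stand within the scatter of each other, so the long chain and the ring are not told apart here.

Open, from the compounds shown here alone, is whether a methoxy or nitro group on the phenyl ring, or a cyclohexyl group in its place, would shift the number. Also open, going by these compounds, is whether a chain longer than that of compound 3, or one carrying an amine, would continue the trend. Nothing beyond the numbers themselves bears on these results.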